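A few compounds are considered here, and "the series" means these few. Any claim that something is new, unique, unknown or untested is made for them only; others in the source may bear on it.

Of the compounds shown here, three have so far been measured in a functional assay on RKO cells (Homo sapiens) for cytotoxicity, read by MTT assay, with a stated time of 48 h; a higher number here means a weaker inhibitor, a lower number a stronger inhibitor. Compound 1 `CN(C)CCNc1ccnc2cc(OCc3ccc(F)cc3)ccc12` gives 580 nM, compound 3 `CN(C)CCNc1ccnc2cc(OCc3ccccc3)ccc12` gives 2350 nM, and compound 2 `CCCCOc1ccc2c(Cl)ccnc2c1` gives 3050 nM. On these numbers compound 2 stands at the top, but its gap to compound 3 lies within the scatter, so the two cannot be ordered; only compound 1 is separated from compound 2 beyond the scatter. For the measured compounds named here, the one step that can be followed between measured compounds, a 4.1-fold higher number from compound 1 to compound 3 (0.61 log units; beyond the scatter), concerns fluoro against hydrogen on an aromatic carbon of a different core and carries no information about the chain of compound 2.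

Compound 4 `CCCCCCOc1ccc2c(Cl)ccnc2c1` differs from compound 2 by ethyl in place of hydrogen on a saturated chain carbon, four bonds along the chain from an oxygen on an aromatic ring. Going by the values given here, no measured pair shows a chain of this kind being lengthened, so the data hold no step that bears on this change. Lacking such a step, the step expected in this assay is a 1.2-fold lower number from compound 2 to compound 4 (0.09 log units; within the scatter), a change that stays within the scatter in either direction. Compound 4 is accordingly estimated at 2500 nM, with a range from 900 nM to 7000 nM to allow for the possibility that the longer chain moves the number either way.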

Compound 4, half-maximal inhibitory concentration: 2720 nM
Beside the measured number, compound 4's estimate is 1.1-fold (0.04 log units) below it, and the stated range covers the measured number.
By their numbers in this assay, from the lowest: compound 1; then compounds 3, 4 and 2 (each within the scatter of the next).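

In this assay, for the compounds shown here, the step of a 1.1-fold lower number from compound 2 to compound 4 (0.05 log units; within the scatter) gives the first direct reading of this change: ethyl in place of hydrogen on a saturated chain carbon, four bonds along the chain from an oxygen on an aromatic ring, leaves the two compounds inseparable. So, for this one pair, lengthening the chain at this place produces no change that can be told from the scatter, in contrast to the only step beyond the scatter so far, a 4.1-fold higher number from compound 1 to compound 3 (0.61 log units; beyond the scatter), which concerns a different place on a different core. No measurement shown offers an explanation for this result.

Going by these compounds, whether the same holds for a chain shorter than that of compound 2 or longer than that of compound 4, or for a chain ending in an amine or a carboxylic acid, remains open. On these data alone, no single change links compound 2 or compound 4 to compound 1 or compound 3, so it is also open how a hexyl chain would behave on the core of compound 1.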